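A few compounds are considered here, and "the series" means these few. Any claim that something is new, unique, unknown or untested is made for them only; others in the source may bear on it.

In an ADME assay on HepG2 cells (Homo sapiens) for cytotoxicity, read by luminescence, CellTiter-Glo and ATP content, with a stated time of 72 h (a lower number here means that less compound is needed, a higher number that more compound is needed for the effect), compound 1 `FC(F)(F)c1ccc(-c2ccc3c(NCCCNCc4ccco4)ccnc3c2)cc1` gives 3470 nM and compound 2 `CN(C)c1cccc(Oc2ccc3c(NCCCNCc4ccco4)ccnc3c2)c1` gives 16000 nM. Compound 2 therefore has the higher of the two numbers, meaning that more of it is needed for the effect. Compound 3 `Fc1ccc(Cc2ccc3c(NCCCNCc4ccco4)ccnc3c2)cc1` has not yet been measured. Within the data shown here, it keeps the shared core and the side chain of compound 2, and only one group changes: 4-fluorobenzyl in place of 3-(dimethylamino)phenoxy on an aromatic carbon. Put simply, 4-fluorobenzyl takes the place of 3-(dimethylamino)phenoxy on an aromatic carbon.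

Among the measured compounds shown here, only one measured step bears on this change: a 4.6-fold higher number from compound 1 to compound 2 (0.66 log units; beyond the scatter). In that step, 3-(dimethylamino)phenoxy took the place of 4-(trifluoromethyl)phenyl, and the number rose by a modest amount. For the measured compounds named here, compound 3 also loses 3-(dimethylamino)phenoxy, and its new group, like the one in compound 1, carries fluorine, so a move back towards the value of compound 1 seems likely. However, 4-fluorobenzyl is a different group, and a single step is thin evidence. The expected change in this assay is a 2.7-fold lower number from compound 2 to compound 3 (0.43 log units; beyond the scatter), a lower number of moderate size. For compound 3, the estimated value is 6000 nM, with an expected range from 2500 nM to 15000 nM.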

Compound 3, half-maximal effective concentration: 5600 nM
Compound 3: middle estimate off by 1.1-fold (0.03 log units), on the high side, and the stated range covers the measured number.
By their numbers in this assay, from the lowest: compounds 1 and 3 (each within the scatter of the next); then compound 2.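

In this assay, putting 4-fluorobenzyl in place of 3-(dimethylamino)phenoxy on this aromatic carbon gives a 2.9-fold lower number from compound 2 to compound 3 (0.46 log units; beyond the scatter) in a second comparison, so compound 2 now stands apart from two different groups rather than from just one. Replacing 4-(trifluoromethyl)phenyl with 4-fluorobenzyl gives a 1.6-fold higher number from compound 1 to compound 3 (0.21 log units; within the scatter) and so leaves these two groups indistinguishable at this position, even though one reaches the shared core through a single added carbon and the other does not. Nothing measured here explains the gap between compound 2 and the other two compounds.

The 3-(dimethylamino)phenoxy group differs from the other two groups in both its oxygen link and its dimethylamino group, so the compounds shown cannot tell which of these parts goes with the higher number. A plain phenoxy group or a 3-(dimethylamino)phenyl group would separate those two parts, and an unsubstituted benzyl group would test whether the fluorine of compound 3 makes any difference.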